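Amide aryl swap in the piperazinyl acetamide series

A few compounds are considered here, and "the series" means these few. Any claim that something is new, unique, unknown or untested is made for them only; others in the source may bear on it.

Measured compounds
compound 1 `Cc1cccc(NC(=O)CN2CCN(c3ncccn3)CC2)c1`: 64.6%
compound 2 `O=C(CN1CCN(c2ccc(Cl)cn2)CC1)Nc1cncnc1`: "not active" (no number reported)

In a functional assay on cells for agonist activity at D(4) dopamine receptor (Homo sapiens), read by TR-FRET and cAMP accumulation, with a stated time of 30 min (on this read-out higher numbers stand for larger maximal responses and lower numbers for smaller maximal responses), compound 1 gives 64.6%. In this assay compound 2 is reported as "not active" (no number reported), so no single number marks where compound 2 stands; all that is known is that no measurable maximal response was recorded for it.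

Compound 3 `Cc1cccc(NC(=O)CN2CCN(c3ccc(Cl)cn3)CC2)c1` is the next compound to be measured in this assay. It differs from compound 2 in one place: 3-methylphenyl in place of pyrimidin-5-yl on an amide-type nitrogen.

No step between measured compounds connects compound 2 and compound 3, and compound 2 itself carries no number, so the size of the step cannot be built from shown data. Compound 3 shares the amide side of compound 1, which gives 64.6%, and the piperazine side of compound 2, which is reported as "not active" (no number reported). A move in the upward direction, out of the inactive range, is therefore held open but not counted on.

The maximal response of compound 3 in this assay is estimated at 38%, with a range from 5% to 72%, and a real chance that the assay again returns no number.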

Compound 3, largest response reached (Emax), in percent of the reference or control that the assay uses: "not active" (no number reported)
Compound 3: no number reported, and the estimate cannot be compared.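

In this assay compound 2 and compound 3 are both reported as not active, so no step can be read between them. Left open is whether any amide aryl group gives a measurable maximal response with the piperazine side shared by compound 2 and compound 3. No measurement shown explains the result.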